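This account rests on a few compounds, and the source may have more. Where it says the series, first, only, none or still open, it means among the compounds named here.

In an assay on isolated protein for inhibition of RAC-alpha serine/threonine-protein kinase (Homo sapiens), read by fluorescence, with a stated time of 30 min, tested at 10 uM (on this read-out higher numbers stand for more inhibition at the one concentration tested (going by the name of the read-out) and lower numbers for less inhibition), compound 1 `O=C(Nc1cc(Sc2ncn[nH]2)c(O)c2ccccc12)c1cccc(Cl)c1` gives 46%, the highest of the three numbers in hand. Within the data shown here, compound 3 `Cn1nnnc1Sc1cc(NC(=O)c2ccc(Cl)cc2)c2ccccc2c1O` gives 13.1% and compound 2 `O=C(Nc1cc(Sc2nncs2)c(O)c2ccccc12)c1ccc(Cl)cc1` gives 7.5%; the only single-point step among the measured compounds, a number 5.6 percentage points higher from compound 2 to compound 3 (within the scatter), concerns the group on the sulfur and stays within the scatter. Compound 4 `Cc1cccc(C(=O)Nc2cc(Sc3ncn[nH]3)c(O)c3ccccc23)c1` differs from compound 1 by methyl in place of chloro on an aromatic carbon. Among the measured compounds shown here, no measured step touches this part of the molecule, and compounds 2 and 3 differ from compound 1 in more than one place, so nothing in hand sizes the change. It is therefore expected to stay within the scatter, with compound 4 estimated at 40% in this assay, ranging from 20% to 60%, an expected step of a number 6 percentage points lower from compound 1 to compound 4 (within the scatter).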

Compound 4, a percentage reported as inhibition, at one concentration (the size of the read-out at that concentration, not a potency): 20.2%
Beside the measured number, compound 4's estimate is 19.8 percentage points above it; measured number inside the range.
By their numbers in this assay, from the lowest: compounds 2, 3 and 4 (each within the scatter of the next, the first and the last beyond it); then compound 1.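

Methyl in place of chloro on this aromatic carbon, meta to a large group, gives a number 25.8 percentage points lower from compound 1 to compound 4 (beyond the scatter), so this is not a neutral exchange. The group on the sulfur is the same in both compounds, and the earlier step of a number 5.6 percentage points higher from compound 2 to compound 3 (within the scatter), at the sulfur, gave no sign of how much this position matters. No measurement in hand accounts for the step.

Going by these compounds, how a methoxy group, an amine or a carboxylic acid would read at this position stays open. Also open, on these data alone, is whether the exchange gives a step of similar size with 1,3,4-thiadiazol-2-yl on the sulfur.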